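From an Amide to an Ester on the Shared Core

The source may report more compounds than this note shows. Statements on the series, on what has been measured and on what is new or still open speak of the compounds shown alone.

Compound 1, `CNC(=O)c1cncc(NS(=O)(=O)c2cc(Cl)ccc2OC)c1`, gives > 20000 nM in an assay on isolated protein for inhibition of alkaline phosphatase, tissue-nonspecific isozyme (Homo sapiens); a lower number here means a stronger inhibitor, a higher number a weaker inhibitor.
Compound 2, `COc1ccc(OC(F)(F)F)cc1S(=O)(=O)Nc1cncc(C(N)=O)c1`, gives 1560 nM in this assay.
Compound 3, `COc1ccc(S(=O)(=O)Nc2cccnc2)c(OC)c1`, gives "not determined" (no result reported) in this assay.

The value of compound 1 is a limit of this assay and not a number, as described by the limit of > 20000 nM in this assay, at which 1 of the 3 values shown sits. Among the three compounds, compound 1 is thus the one with only a limit, compound 2 supplies the only single number, and compound 3 carries no result at all. Compound 4, `COC(=O)c1cncc(NS(=O)(=O)c2cc(Cl)ccc2OC)c1`, is the next compound to be tested. It differs from compound 1 in one place: methoxy in place of methylamino on a carbonyl carbon, or methylcarbamoyl turning into methoxycarbonyl when the change is read one bond further out. Among the compounds with values here, no step between two measured compounds is available to show how large such a change runs in this assay, so the expectation rests on compound 1 alone. The step that the limit leaves unreadable from compound 1 to compound 4 is expected to be none beyond the scatter. Compound 4 is therefore estimated at 25000 nM, within a range from 5000 nM to 100000 nM.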

Compound 4, half-maximal inhibitory concentration: > 20000 nM
Compound 4: only a limit was reported (the forecaster's own chance of this, stated with the estimate: 65%); the middle value is on the limit's open side.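

No step can be read from compound 1 to compound 4, because both compounds give only a limit and not a number in this assay: the limit of > 20000 nM in this assay, at which 2 of the 4 values shown sit.

The compounds shown leave open whether methoxy in place of methylamino on a carbonyl carbon changes the inhibition at all.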